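Swapping a Methyl for Fluoro on a Thienopyrimidine Amide

The source may report more compounds than this note shows. Statements on the series, on what has been measured and on what is new or still open speak of the compounds shown alone.

Compound 1, `Cc1ccc(-n2nc(C(=O)Nc3ccc(Oc4ncnc5ccsc45)c(F)c3)c(C)cc2=O)cc1`, and compound 2, `Cc1cc(=O)n(-c2ccc(F)cc2)nc1C(=O)Nc1ccc(Oc2ncnc3ccsc23)c(F)c1`, share one core and differ only in one group on an outer ring. The change between them, (fluoro in place of methyl on an aromatic carbon), is measured: in a functional assay on A549 cells (Homo sapiens) for cytotoxicity, read by MTT assay, with a stated time of 72 h (on this read-out higher numbers stand for weaker inhibition and lower numbers for stronger inhibition), compound 1 gives 5890 nM, and compound 2 gives 580 nM. This amounts to a 10-fold lower number from compound 1 to compound 2 (1.01 log units; beyond the scatter).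

Compound 3, `Cc1ccc(-n2nc(C(=O)Nc3ccc(Oc4ncnc5sccc45)cc3)c(C)cc2=O)cc1`, carries a core that differs from the core of compound 1; the difference between the two cores is not broken down here. In this assay compound 3 gives only a limit, > 40000 nM, which is not a number but the edge of what the test can report. The same limit is noted in the limit of > 40000 nM in this assay, at which 1 of the 3 values shown sits.

Compound 4, `Cc1cc(=O)n(-c2ccc(F)cc2)nc1C(=O)Nc1ccc(Oc2ncnc3sccc23)cc1`, has not yet been measured. It stands to compound 3 as compound 2 stands to compound 1: the difference, (fluoro in place of methyl on an aromatic carbon), is the same change at the same kind of place.

Because of a 10-fold lower number from compound 1 to compound 2 (1.01 log units; beyond the scatter), a step of roughly an at least 4.0-fold lower number from compound 3 to compound 4 (0.60 log units; beyond the scatter) is expected from compound 3 to compound 4, though its starting point is only a limit, so the true size is uncertain. In this assay compound 4 is expected to give about 10000 nM, with a likely range from 2500 nM to 40000 nM, and a real chance that only a limit is reported again.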

Compound 4, half-maximal inhibitory concentration: 7050 nM
Compound 4: middle estimate off by 1.4-fold (0.15 log units), on the high side, and the stated range covers the measured number.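

On the core of compound 3, the change from 4-methylphenyl to 4-fluorophenyl gives, in this assay, an at least 5.6-fold lower number from compound 3 to compound 4 (0.75 log units; beyond the scatter), so the direction seen on the core of compound 1 appears on this second core as well. Set side by side, the two steps read: the same change on two cores in this assay, a 10-fold lower number (1.01 log units; beyond the scatter) from compound 1 to compound 2 and an at least 5.6-fold lower number (0.75 log units; beyond the scatter) from compound 3 to compound 4; the limit leaves it open whether they differ

Compound 3 rests on a limit rather than a number, so these two pairs show a shared direction but not whether the change is worth the same amount on both cores, and two pairs do not make a general rule for the series: the limit of > 40000 nM in this assay, at which 1 of the 4 values shown sits.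

The compounds shown carry only methyl and fluoro at this place on the outer ring, so it remains open whether chloro, methoxy or an amine there would fall in the same direction. A true number for a 4-methylphenyl compound on the core of compound 3 would be needed to fix the size of the second step, and a third core would be needed to test whether the direction holds beyond these two pairs.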